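Propylamino to Benzylamino on the Shared Core

The compounds below may be only part of what the source reports. "The series", "measured", "known", "first", "only" and "open" are said of these compounds alone.

Compound 1, `COc1cc2c(cc1O)C(=O)CC(C(=O)O)O2`, carries a carboxylic acid on the shared core. In a functional assay (brain) for inhibition, with Rattus norvegicus as the target (on this read-out higher numbers stand for weaker inhibition and lower numbers for stronger inhibition), compound 1 gives only a limit, > 300000 nM. Compound 2, `CCCNC(=O)C1CC(=O)c2cc(O)c(OC)cc2O1`, is the corresponding amide, with propylamino in place of hydroxy on a carbonyl carbon. In this assay compound 2 likewise gives only a limit, > 300000 nM. The step that the two limits leave unreadable from compound 1 to compound 2 can therefore be read neither in size nor in direction; both values rest at the limit of > 300000 nM in this assay, at which 2 of the 2 values shown sit. Compound 2 thus stands at that limit, with no number of its own.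

Compound 3, `COc1cc2c(cc1O)C(=O)CC(C(=O)NCc1ccccc1)O2`, differs from compound 2 as follows: phenyl in place of ethyl on a saturated chain carbon bound to an amide-type nitrogen. Among the compounds with values here, no measured step bears on this change: the only step between measured compounds concerns the carbonyl carbon and is itself unreadable. With both known compounds at the limit, nothing in the data points toward stronger or weaker inhibition for compound 3. Compound 3 is therefore expected to give 300000 nM in this assay, within a range from 100000 nM to 1000000 nM, most likely again only as a limit. The step of a number no higher from compound 2 to compound 3 (the limit leaves the size open) is thus expected to be no change beyond the scatter.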

Compound 3, half-maximal inhibitory concentration: > 300000 nM
Compound 3: no number, only a limit (the forecaster's own chance of this, stated with the estimate: 75%); the middle value lies on the limit itself.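

In this assay, within the data shown here, compound 3 again gives only a limit, so no step among compound 1, compound 2 and compound 3 can be read in size or in direction: the limit of > 300000 nM in this assay, at which 3 of the 3 values shown sit. The compounds shown leave open whether any change on the shared core would give a measurable number in this assay.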